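The source may hold more compounds than are shown below. What is called first, only, known or untested is meant among the compounds shown, and "the series" means these compounds.

Measured in an assay on isolated protein for inhibition of Nitric oxide synthase, inducible (Homo sapiens), read by scintillation counting, with a stated time of 30 min, tested at 50 uM; a lower number here means less inhibition, a higher number more inhibition at the concentration tested (going by the name of the read-out):
compound 1 `CC(=O)N1N=C(c2cc(Cl)ccc2N)SC1(C)C` gives 72.8%
compound 2 `CCC(=O)N1N=C(c2cc(Cl)ccc2N)SC1(C)C` gives 1.07%
compound 3 `CC(=O)N1N=C(c2ccccc2N)SC1(C)C` gives 22.9%

Compound 4 `CCC(=O)N1N=C(c2ccccc2N)SC1(C)C` is not yet measured. The core of compound 3 differs from the core of compound 1 by hydrogen in place of chloro on an aromatic carbon, and that difference alone gave a number 49.9 percentage points lower from compound 1 to compound 3 (beyond the scatter). Compound 4 stands to compound 3 as compound 2 stands to compound 1: methyl in place of hydrogen on a saturated chain carbon bound to a carbonyl carbon and methyl in place of hydrogen on a saturated chain carbon bound to a carbonyl carbon are the same change at the same place, and in the measured pair it gave a number 71.7 percentage points lower from compound 1 to compound 2 (beyond the scatter). Compound 3 starts lower, at 22.9%, so less room remains downward. The step from compound 3 to compound 4 in this assay is therefore expected to be smaller in size, about a number 19.9 percentage points lower from compound 3 to compound 4 (beyond the scatter), resting on the drop seen in a number 71.7 percentage points lower from compound 1 to compound 2 (beyond the scatter). For compound 4 the estimate is 3%, expected between -6% and 16%.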

Compound 4, a percentage reported as inhibition, at one concentration (the size of the read-out at that concentration, not a potency): 19.2%
Estimate against measurement, compound 4: 16.2 percentage points below; measured number above the stated range.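

In this assay the acetyl to propanoyl change gives a number 3.7 percentage points lower from compound 3 to compound 4 (within the scatter), so the large loss on the chloro core does not carry over to the core without chloro, while the chloro to hydrogen change among the propanoyl compounds gives a number 18.1 percentage points higher from compound 2 to compound 4 (beyond the scatter). The effect of the acetyl to propanoyl change depends on the core: the same change on two cores in this assay, a number 71.7 percentage points lower (beyond the scatter) from compound 1 to compound 2 and a number 3.7 percentage points lower (within the scatter) from compound 3 to compound 4, 68 percentage points apart, beyond the scatter of two such steps. The effect of the chloro to hydrogen change depends on the acyl group, but four compounds at one concentration give neither potencies nor a reason for this dependence: the same change on two cores in this assay, a number 49.9 percentage points lower (beyond the scatter) from compound 1 to compound 3 and a number 18.1 percentage points higher (beyond the scatter) from compound 2 to compound 4, 68 percentage points apart, beyond the scatter of two such steps.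

Open, on these data alone, is how a longer chain, such as butanoyl, behaves on either core. Also open, as far as these compounds go, is whether fluoro or methoxy in place of chloro would keep the pattern of compound 1 and compound 2.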